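This account rests on a few compounds, and the source may have more. Where it says the series, first, only, none or still open, it means among the compounds named here.

Compound 1 `Cc1cccc2c(=O)c(-c3nn[nH]n3)c[nH]c12` gives > 5 mg/kg in a functional assay on the whole organism (strain Sprague-Dawley) for inhibition, with Rattus norvegicus as the target; on this read-out lower numbers stand for an effect already at smaller amounts and higher numbers for an effect only at larger amounts of compound.
Compound 2 `COc1ccc2c(=O)c(-c3nn[nH]n3)c[nH]c2c1` gives 10 mg/kg in this assay.
Compound 3 `Cc1cccc2cc(-c3nn[nH]n3)cnc12` gives < 25 mg/kg in this assay.

Compound 1 stands on a limit of the assay rather than a number: its result of > 5 mg/kg is the limit of > 5 mg/kg in this assay, at which 1 of the 3 values shown sits. Among the three results shown, one further value is also a limit, namely the reading of compound 3, which is the limit of < 25 mg/kg in this assay, at which 1 of the 3 values shown sits. Only compound 2 has a plain number, and in this assay compound 2 gives 10 mg/kg.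

The unmeasured compound 4 `CS(=O)(=O)c1cccc2c(=O)c(-c3nn[nH]n3)c[nH]c12` differs from compound 1 in one place: methylsulfonyl in place of methyl on an aromatic carbon. Among the measured compounds shown here, no step between measured compounds is available to set a scale for this change, so the size of the step from compound 1 to compound 4 has to be guessed from the spread of the values shown. A step that the limit leaves unreadable from compound 1 to compound 4 is expected, with no certain direction, since compound 1 itself is known only as a limit. Compound 4 is therefore estimated at 10 mg/kg, within 3 mg/kg to 30 mg/kg.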

Compound 4, minimum effective dose: 10 mg/kg
Beside the measured number, compound 4's estimate shows no gap at the digits printed, within the range that was stated.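

No step can be read between compound 4 and compound 1. Compound 1 gives > 5 mg/kg which is a limit and not a number. On these data alone, whether methylsulfonyl in place of methyl on an aromatic carbon shifts the result in this assay at all, and in which direction, stays open.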